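Hydroxy to methoxy on the cyclohexyl amide: protein binding

The source may hold more compounds than are shown below. What is called first, only, known or untested is meant among the compounds shown, and "the series" means these compounds.

compound 1 `CNC(=O)c1cc(C(=O)N[C@H]2CC[C@H](O)CC2)c([C@@H](C)c2cccc(Cl)c2)o1` gives 0.14 in an ADME assay on blood (Homo sapiens) for protein binding, read by LC-MS, using equilibrium dialysis; a higher number here means a larger unbound share of the compound, a lower number a smaller unbound share
compound 2 `CNC(=O)c1cc(C(=O)N[C@H]2[C@@H]3C[C@H](O)C[C@@H]32)n([C@@H](C)c2cccc(Cl)c2)n1` gives "not determined" (no result reported) in this assay
compound 3 `CNC(=O)c1cc(C(=O)N[C@H]2CC[C@H](O)CC2)n([C@@H](C)c2ccccc2)n1` gives 0.44 in this assay

Among the numbers in hand, compound 3 stands highest at 0.44 and compound 1 gives 0.14 in this assay. The gap between them lies beyond the scatter. These two compounds differ in more than one place, so their gap says nothing about any single change. Compound 2 adds no number to the comparison.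

The next compound is compound 4 `CNC(=O)c1cc(C(=O)N[C@H]2CC[C@H](OC)CC2)n([C@@H](C)c2ccccc2)n1`. Its change from compound 3 is methyl in place of hydrogen on an oxygen on a saturated carbon, with methyl in place of hydrogen on an oxygen on a saturated carbon, which turns hydroxy into methoxy. Going by the values given here, no measured pair carries this change, so the expectation rests on the structural change alone and remains a judgement.

A small fall in this assay is expected, most likely not beyond the scatter. The expected step is a 1.4-fold lower number from compound 3 to compound 4 (0.14 log units; within the scatter) in size. The estimated value for compound 4 is 0.32 within an expected range of 0.17 to 0.55 in this series.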

Compound 4, unbound fraction: 0.29
Estimate against measurement, compound 4: 1.1-fold (0.04 log units) above, and the stated range covers the measured number.
By their numbers in this assay, from the lowest: compound 1; then compounds 4 and 3 (each within the scatter of the next).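

In this assay, going by these compounds alone, the change from hydroxy to methoxy gives a 1.5-fold lower number from compound 3 to compound 4 (0.18 log units; within the scatter) as the first comparison that differs in one place. On this single pair, the oxygen on the saturated carbon takes methyl in place of hydrogen with no shift in unbound fraction beyond the scatter. No measurement at hand explains this step.

From the compounds shown here alone, it remains open whether the same change reads alike on the core of compound 1, which carries the same 4-hydroxycyclohexyl amide. Also open, going by these compounds, is how an amine, a carboxylic acid or a longer chain such as ethoxy in place of the hydroxy would read in this assay.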